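Swapping a chlorophenyl for a bromophenyl on the side chain

The compounds below may be only part of what the source reports. "The series", "measured", "known", "first", "only" and "open" are said of these compounds alone.

compound 1 `NC1=NC2(CCSCC2)N(OCCCOc2ccc(Cl)c(Cl)c2)C(N)=N1` gives 140 nM
compound 2 `NC1=NC2(CCOCC2)N(OCCCOc2ccccc2Cl)C(N)=N1` gives 660 nM

In a functional assay on HL-60 cells (Homo sapiens) for antiproliferative activity, read by MTT assay, with a stated time of 72 h (on this read-out higher numbers stand for weaker inhibition and lower numbers for stronger inhibition), compound 2 holds the higher of these two numbers (660 nM), so it inhibits more weakly than compound 1, by a gap beyond the scatter. Compound 3 `NC1=NC2(CCOCC2)N(OCCCOc2cccc(Br)c2)C(N)=N1` keeps the core of compound 2 but has 3-bromophenyl in place of 2-chlorophenyl on an oxygen on a saturated carbon. For the measured compounds named here, no measured pair shows this change alone, so only a small shift is expected, with none beyond the scatter. The expected step (a 1.5-fold lower number from compound 2 to compound 3 (0.17 log units; within the scatter)) leans slightly lower. The estimate for compound 3 is 450 nM (expected range 150 nM to 1300 nM).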

Compound 3, half-maximal inhibitory concentration: 560 nM
For compound 3 the middle estimate is 1.2-fold (0.09 log units) below the measured one; measured number inside the range.
By their numbers in this assay, from the lowest: compound 1; then compounds 3 and 2 (each within the scatter of the next).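

In this assay, 3-bromophenyl in place of 2-chlorophenyl on an oxygen on a saturated carbon gives a 1.2-fold lower number from compound 2 to compound 3 (0.07 log units; within the scatter), so the two compounds cannot be told apart. This position therefore tolerates this swap, in which the halogen and its place on the ring change together, so neither change can be judged alone. Nothing measured here points to a cause for this result. Still open, as far as these compounds go, is whether an unsubstituted phenyl, or a phenyl carrying a methoxy group or a nitrile, would give a similar number.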